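Chloro scan on the benzamide ring of the thiadiazole series

The source may hold more compounds than are shown below. What is called first, only, known or untested is meant among the compounds shown, and "the series" means these compounds.

Compound 1 `O=C(Nc1nnc(-c2ccc(Cl)cc2)s1)c1ccccc1O` gives 1150 nM in a functional assay on B16-F10 cells (Mus musculus) for antiproliferative activity, read by MTT assay, with a stated time of 48 h; a lower number here means a stronger inhibitor, a higher number a weaker inhibitor. Compound 2 `O=C(Nc1nnc(-c2ccc(Cl)cc2)s1)c1cc(Cl)ccc1O` gives 310 nM in this assay; the change chloro in place of hydrogen on an aromatic carbon made a step of a 3.7-fold lower number from compound 1 to compound 2 (0.57 log units; beyond the scatter). Compound 3 `O=C(Nc1nnc(-c2ccccc2)s1)c1ccccc1` gives 5150 nM in this assay; the difference between the core of compound 3 and the core of compound 1 is not broken down here. Compound 4 `O=C(Nc1nnc(-c2ccccc2)s1)c1ccc(Cl)cc1` carries the change (chloro in place of hydrogen on an aromatic carbon), the same kind of change as in compound 2, but there the chloro sat meta to a large group and para to a hydroxy group, here it sits para to a large group. Because the step of a 3.7-fold lower number from compound 1 to compound 2 (0.57 log units; beyond the scatter) rests on a differently placed chloro, a smaller step of a 2.1-fold lower number from compound 3 to compound 4 (0.33 log units; beyond the scatter) is expected in this assay. Compound 4 is therefore estimated at 2400 nM, between 900 nM and 6500 nM.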

Compound 4, half-maximal inhibitory concentration: 4650 nM
Compound 4: the middle estimate sits 1.9-fold (0.29 log units) below what was measured, within the range that was stated.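

In this assay the change from phenyl to 4-chlorophenyl gives a 1.1-fold lower number from compound 3 to compound 4 (0.04 log units; within the scatter), so no gain can be claimed for it on this core. The same kind of change does not carry over with one size between the two cores: the same change on two cores in this assay, a 3.7-fold lower number (0.57 log units; beyond the scatter) from compound 1 to compound 2 and a 1.1-fold lower number (0.04 log units; within the scatter) from compound 3 to compound 4, 3.3-fold (0.52 log units) apart, beyond the scatter of two such steps. For the compounds shown here, what this does not show is whether the core or the placement of the chloro sets that gap: the two pairs differ in both, and no pair here separates them.

Left open is whether a chloro placed as in compound 2 would give a larger step on the core of compound 3. Also open, on these data alone, is how a methoxy group or an amine in place of the chloro of compound 4 would compare.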